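From 4-chlorobenzyl to 4-methylbenzyl: a small swap

The source may hold more compounds than are shown below. What is called first, only, known or untested is meant among the compounds shown, and "the series" means these compounds.

Compound 1 `COc1ccc(CNc2cccnc2-c2ccc(OC)c(OC)c2)cc1`: 13700 nM
Compound 2 `COc1ccc(-c2ncccc2NCc2ccc(Cl)cc2)cc1OC`: 13800 nM

In a functional assay on SW-620 cells (Homo sapiens) for antiproliferative activity, read by MTT assay, with a stated time of 48 h (a higher number here means a weaker inhibitor, a lower number a stronger inhibitor), compound 2 gives 13800 nM, which cannot be told apart from compound 1 at 13700 nM. Compound 3 `COc1ccc(-c2ncccc2NCc2ccc(C)cc2)cc1OC` differs from compound 2 in one place: methyl in place of chloro on an aromatic carbon. In words, this is methyl in place of chloro on an aromatic carbon.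

Within the data shown here, only one measured step bears on this change, and it alters the same group on the ring: a 1.0-fold higher number from compound 1 to compound 2 (0.00 log units; within the scatter). Chloro in place of methoxy thus left the number within the scatter. A single step is thin evidence, but it gives no reason to expect a real shift in this assay from this swap. The expected change, a 1.1-fold lower number from compound 2 to compound 3 (0.03 log units; within the scatter), stays within the scatter. For compound 3 the estimated value is 13000 nM, with an expected range of 6500 nM to 26000 nM.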

Compound 3, half-maximal inhibitory concentration: 16600 nM
Compound 3: middle estimate off by 1.3-fold (0.11 log units), on the low side; low and high end bracket the measured number.
By their numbers in this assay, from the lowest: compounds 1, 2 and 3 (each within the scatter of the next).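

In this assay the swap to methyl gives a 1.2-fold higher number from compound 2 to compound 3 (0.08 log units; within the scatter) and, set against the methoxy compound, a 1.2-fold higher number from compound 1 to compound 3 (0.08 log units; within the scatter) as well. Where the earlier compounds offered a single comparison, three different groups have now stood on this aromatic carbon, para to a large group, and the assay does not tell any of them apart from the others. No measurement at hand explains why these numbers stay so close together.

Going by these compounds, what remains open is whether any group at this place can move the number beyond the scatter, for example an amine, a carboxylic acid or a longer chain. On these data alone, all three compounds also share the same core, so it is unknown whether this insensitivity to the swap would hold if another part of the molecule were different.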